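Methyl step from compound 1 to compound 4

The source may report more compounds than this note shows. Statements on the series, on what has been measured and on what is new or still open speak of the compounds shown alone.

Measured so far:
compound 1 `C=CC(=O)Nc1nc(-c2ccccc2)cs1` gives 18600 nM
compound 2 `C=CC(=O)Nc1nc(-c2ccccc2Cl)cs1` gives 12300 nM
compound 3 `C=CC(=O)Nc1nc(-c2cccc(Cl)c2)cs1` gives 11900 nM

In a functional assay on HCT-116 cells (Homo sapiens) for antiproliferative activity, read by MTT assay, with a stated time of 72 h (on this read-out higher numbers stand for weaker inhibition and lower numbers for stronger inhibition), compound 1 sits level with compound 2 and compound 3 , its steps to both lying within the scatter. Compound 4 `C=CC(=O)Nc1nc(-c2ccc(C)cc2)cs1` differs from compound 1 by methyl in place of hydrogen on an aromatic carbon. Within the data shown here, no measured step introduces methyl. The closest guides are two changes of chloro in place of hydrogen on an aromatic carbon , a 1.5-fold lower number from compound 1 to compound 2 (0.18 log units; within the scatter) and a 1.6-fold lower number from compound 1 to compound 3 (0.19 log units; within the scatter). Neither leaves the scatter , so no step beyond the scatter is expected here , in either direction. The expected step is a 1.2-fold lower number from compound 1 to compound 4 (0.09 log units; within the scatter). Compound 4 is estimated at 15000 nM, with an expected range of 7500 nM to 30000 nM.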

Compound 4, half-maximal inhibitory concentration: 15300 nM
Estimate against measurement, compound 4: 1.0-fold (0.01 log units) below; low and high end bracket the measured number.
By their numbers in this assay, from the lowest: compounds 3, 2, 4 and 1 (each within the scatter of the next).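

In this assay, methyl on an aromatic carbon para to a large group gives a 1.2-fold lower number from compound 1 to compound 4 (0.08 log units; within the scatter) and so stays within the scatter. Compound 2 and compound 3 carry chloro elsewhere on the ring, so this position and a carbon substituent are new, and neither produces a step beyond the scatter. No measurement available here explains this result.

An amine, a carboxylic acid or a longer chain at this position may or may not leave the scatter. Going by these compounds, whether methyl behaves alike at the other ring positions also remains open.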